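Working notes: heteroaryl exchange from compound 1 to compound 4

The compounds below may be only part of what the source reports. "The series", "measured", "known", "first", "only" and "open" are said of these compounds alone.

Measured so far:
- compound 1, `CCN(c1ccc(C#N)c(Cl)c1)c1cc(-c2ccncc2)ccc1C`: 1730 nM
- compound 2, `N#Cc1ccc(N2CCc3cc(-c4cnc5ccccc5c4)ccc32)cc1C(F)(F)F`: "not determined" (no result reported)
- compound 3, `Cc1noc(C)c1-c1cccc2c1CCCN2c1ccc(C#N)c(C(F)(F)F)c1`: "not determined" (no result reported)

In an ADME assay on L02 cells (Homo sapiens) for antiproliferative activity, read by CCK-8 assay, with a stated time of 6 days (on this read-out higher numbers stand for weaker inhibition and lower numbers for stronger inhibition), compound 1 gives 1730 nM. Among the compounds with values here, this is the only number in hand; compound 2 and compound 3 were not determined in this assay, so compound 1 cannot be placed against any other compound, and no step between measured compounds exists in this set.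

Compound 4, `CCN(c1ccc(C#N)c(Cl)c1)c1cc(-c2c[nH]nc2C)ccc1C`, is the next entry. The change from compound 1 is 3-methyl-1H-pyrazol-4-yl in place of pyridin-4-yl on an aromatic carbon. The shared core of compound 1 is kept; only the heteroaryl group on that aromatic carbon is exchanged, and the counted difference shows a five-membered ring with 2 hetero atoms carrying 1 hydrogen-bond donor where a six-membered ring with 1 hetero atom and no donor stood before.

Within the data shown here, with no measured step to lean on, the expectation is drawn from compound 1 alone. Antiproliferative read-outs on this cell line have not, in this set, been shown to move with such exchanges, so the expected step of a 1.2-fold higher number from compound 1 to compound 4 (0.06 log units; within the scatter) is taken as none beyond the scatter. Compound 4 is therefore estimated at 2000 nM, with a range from 700 nM to 6000 nM, the width reflecting the absence of any comparison pair.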

Compound 4, half-maximal inhibitory concentration: 5780 nM
For compound 4 the middle estimate is 2.9-fold (0.46 log units) below the measured one, and the stated range covers the measured number.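

On this assay, placing 3-methyl-1H-pyrazol-4-yl instead of pyridin-4-yl on this aromatic carbon gives a 3.3-fold higher number from compound 1 to compound 4 (0.52 log units; beyond the scatter). This first readable step shows that the read-out responds to the heteroaryl group at this position, here moving towards weaker inhibition beyond the usual scatter. The exchange alters ring size, the number of ring hetero atoms and the hydrogen-bond donor count together, so this single step cannot assign the change to any one of them, and no measurement on hand explains it.

The compounds shown leave open how 1H-pyrazol-4-yl without the methyl group or pyridin-3-yl would read on the same carbon, which would begin to separate the contributions of the methyl group, the ring and the donor. They also leave open whether an amine or a carboxylic acid at this position would move the number further in either direction, and whether the same heteroaryl exchange would give a similar step on a different core.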